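Methoxy Removal on a Chloro-Styryl Core: Expected Potency Shift

The source may hold more compounds than are shown below. What is called first, only, known or untested is meant among the compounds shown, and "the series" means these compounds.

Measured compounds:
Compound 1, `Fc1ccc(/C=C/c2cc3ccccc3nc2Cl)cc1`, 15100 nM
Compound 2, `COc1ccc2nc(Cl)c(/C=C/c3ccc(F)cc3)cc2c1`, 14100 nM
Compound 3, `COc1ccc2nc(Cl)c(/C=C\c3cc(C(F)(F)F)cc(C(F)(F)F)c3)cc2c1`, 4700 nM

Three compounds sharing one core were tested in a functional assay on MCF7 cells (Homo sapiens) for antiproliferative activity, read by sulforhodamine B assay, with a stated time of 72 h; a lower number here means a stronger inhibitor, a higher number a weaker inhibitor. Compound 1 gives 15100 nM, and compound 2 gives 14100 nM. The change between them is hydrogen in place of methoxy on an aromatic carbon, and the step from compound 2 to compound 1 is a 1.1-fold higher number from compound 2 to compound 1 (0.03 log units; within the scatter). Compound 3 gives 4700 nM, the lowest number of the three; its nearest neighbour is compound 2, its furthest compound 1, and both gaps lie beyond the usual scatter. How the core of compound 3 differs from that of compound 2 is not broken down here.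

Compound 4, `FC(F)(F)c1cc(/C=C\c2cc3ccccc3nc2Cl)cc(C(F)(F)F)c1`, has not yet been measured in this assay. It differs from compound 3 by hydrogen in place of methoxy on an aromatic carbon, the same kind of change as that from compound 2 to compound 1. Since that earlier step was within the scatter, the analogous step from compound 3 to compound 4 is expected to be of similar size, a 1.1-fold higher number from compound 3 to compound 4 (0.04 log units; within the scatter), because compound 3 gives 4700 nM and the earlier pair moved so little. The estimate for compound 4 in this assay is therefore 5200 nM, expected to fall between 2200 nM and 12500 nM.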

Compound 4, half-maximal inhibitory concentration: 7460 nM
The estimate for compound 4 lay 1.4-fold (0.16 log units) below the measured number, and the stated range covers the measured number.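

In this assay, putting hydrogen in place of methoxy on an aromatic carbon of the core of compound 3 gives a 1.6-fold higher number from compound 3 to compound 4 (0.20 log units; within the scatter), and this step agrees with the one seen earlier for the same change on another core: the same change on two cores in this assay, a 1.1-fold higher number (0.03 log units; within the scatter) from compound 2 to compound 1 and a 1.6-fold higher number (0.20 log units; within the scatter) from compound 3 to compound 4, 1.5-fold (0.17 log units) apart, within the scatter of two such steps. Across these two pairs, then, the change carries from one core to the other without a step beyond the scatter, and the methoxy group can be lost from either core with no clear change in the number. This does not show that methoxy and hydrogen are interchangeable throughout the series, since two pairs in one cell assay say nothing about other cores or other read-outs, and they give no reason why the change does so little.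

The compounds shown leave open whether a different group on that same aromatic carbon, such as a hydroxyl, an amine, a carboxylic acid or a longer chain like ethoxy, would give a step beyond the scatter. They also leave open what would follow if the chlorine shared by all four compounds gave way to an amine or a nitrile.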